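The source may report more compounds than this note shows. Statements on the series, on what has been measured and on what is new or still open speak of the compounds shown alone.

Working notes on the series.

Compound 1 `Oc1cccc(-c2cc(-c3ccccc3)cc(-c3ccccc3)n2)c1` gives 0% in an assay on isolated protein for inhibition of DNA topoisomerase 1 (Homo sapiens), with a stated time of 30 min, tested at 20 uM; a higher number here means a stronger effect of the compound at the concentration tested, a lower number a weaker effect. Compound 2 `Oc1cccc(-c2cc(-c3ccccc3)cc(-c3cccs3)n2)c1` gives 5.8% in this assay. The step of a number 5.8 percentage points higher from compound 1 to compound 2 (within the scatter) corresponds to the change (thiophen-2-yl in place of phenyl on an aromatic carbon).

Compound 3 `Oc1cccc(-c2cc(-c3ccccc3)nc(-c3ccccc3)c2)c1` shares its atoms with compound 1 but joins them differently; the difference between the two cores is not broken down here. In this assay compound 3 gives 0%, level with compound 1 and within the scatter of compound 2.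

Compound 4 `Oc1cccc(-c2cc(-c3ccccc3)nc(-c3cccs3)c2)c1` is not yet measured. It carries the same change as compound 2, namely (thiophen-2-yl in place of phenyl on an aromatic carbon). Since the earlier step of a number 5.8 percentage points higher from compound 1 to compound 2 (within the scatter) stayed within the scatter, the step from compound 3 to compound 4 is expected to be small as well, estimated at a number 3 percentage points higher from compound 3 to compound 4 (within the scatter). Compound 4 is therefore expected to give about 3% in this assay, between 0% and 15%.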

Compound 4, a percentage reported as inhibition, at one concentration (the size of the read-out at that concentration, not a potency): 2%
The estimate for compound 4 lay 1 percentage points above the measured number; the range from low to high includes it.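

Thiophen-2-yl in place of phenyl on an aromatic carbon gives a number 2 percentage points higher from compound 3 to compound 4 (within the scatter). Set beside the earlier step, the same change shows no difference between the two cores in this assay: the same change on two cores in this assay, a number 5.8 percentage points higher (within the scatter) from compound 1 to compound 2 and a number 2 percentage points higher (within the scatter) from compound 3 to compound 4, 3.8 percentage points apart, within the scatter of two such steps

This shows that the change stays small on both cores, but both steps lie at the low end of the read-out at a single concentration, so they do not show how the change would carry over to a core with a clear effect. Going by these compounds, it remains open whether an amine or a carboxylic acid in place of the phenyl or thiophen-2-yl group would move the read-out beyond the scatter. On these data alone, the effect of replacing the 3-hydroxyphenyl group also remains open.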